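A few compounds are considered here, and "the series" means these few. Any claim that something is new, unique, unknown or untested is made for them only; others in the source may bear on it.

Compound 1 `CCCCCCC1(O)C(=O)Nc2ccc(Nc3ccc(OC)cc3)cc21` and compound 3 `CCCCCCC1(O)C(=O)Nc2ccc(Nc3ccc(C)cc3)cc21` share a core; their difference is methyl in place of methoxy on an aromatic carbon. In a functional assay on NCI-H460 cells (Homo sapiens) for antiproliferative activity, read by MTT assay, with a stated time of 48 h (on this read-out higher numbers stand for weaker inhibition and lower numbers for stronger inhibition), compound 1 gives only the limit of the assay, > 100000 nM. Compound 3 likewise gives only a limit, > 100000 nM. The step between them, a step that the two limits leave unreadable from compound 1 to compound 3, is therefore not readable. Compound 2 `COc1ccc(Nc2ccc3c(c2)C(O)(Cc2ccccc2)C(=O)N3)cc1` differs from compound 1 by phenyl in place of pentyl on a saturated chain carbon bound to a saturated ring carbon; compound 2 also gives only a limit, > 100000 nM, so a step that the two limits leave unreadable from compound 1 to compound 2 cannot be sized either, since all three values sit at the limit of > 100000 nM in this assay, at which 3 of the 3 values shown sit. Compound 4 `Cc1ccc(Nc2ccc3c(c2)C(O)(Cc2ccccc2)C(=O)N3)cc1` differs from compound 3 by phenyl in place of pentyl on a saturated chain carbon bound to a saturated ring carbon, the same change as from compound 1 to compound 2, at the same place. Beside a step that the two limits leave unreadable from compound 1 to compound 2, the step of a number no higher from compound 3 to compound 4 (the limit leaves the size open) is expected to be unreadable as well, because compound 3 gives > 100000 nM. Compound 4 is therefore estimated at 100000 nM, between 30000 nM and 300000 nM.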

Compound 4, half-maximal inhibitory concentration: 31600 nM
Beside the measured number, compound 4's estimate is 3.2-fold (0.50 log units) above it; measured number inside the range.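

In this assay, phenyl in place of pentyl on the core of compound 3 gives an at least 3.1-fold lower number from compound 3 to compound 4 (0.50 log units; beyond the scatter), and methyl in place of methoxy with the phenyl kept gives an at least 3.1-fold lower number from compound 2 to compound 4 (0.50 log units; beyond the scatter). Each is a bound set by a limit and not a measured size. The same phenyl change on the core of compound 1 and the other steps cannot be read, so the series does not show that the change carries over from one core to the other, nor how large it is on either: the limit of > 100000 nM in this assay, at which 3 of the 4 values shown sit.

The compounds shown leave open how large the step from pentyl to phenyl really is. They also leave open whether an amine or a carboxylic acid in place of the methyl would give a lower number than compound 4.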